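The source may report more compounds than this note shows. Statements on the series, on what has been measured and on what is new or still open speak of the compounds shown alone.

The measured compounds and their values in a functional assay on B16-F10 cells (Mus musculus) for antiproliferative activity, read by CCK-8 assay, with a stated time of 48 h; on this read-out lower numbers stand for stronger inhibition and higher numbers for weaker inhibition:
compound 1 `COc1ccc(/C=C\c2cc(OC)c(OC)c(OC)c2)cc1OCc1ccc(CN2CCCCC2C(=O)NCCN)cc1` gives 4600 nM;
compound 2 `COc1ccc(/C=C\c2cc(OC)c(OC)c(OC)c2)cc1OCc1ccc(C=O)cc1` gives 4200 nM;
compound 3 `COc1ccc(/C=C\c2cc(OC)c(OC)c(OC)c2)cc1OCc1ccc(CNCCNC(C)=O)cc1` gives 2500 nM.

Compound 3 has the lowest of the three numbers, yet both other compounds lie within the scatter of it. Compound 4 `COc1ccc(/C=C\c2cc(OC)c(OC)c(OC)c2)cc1OCc1ccc(CNCCN(C)C)cc1` is the next step: dimethylamino in place of acetamido on a saturated chain carbon, two bonds along the chain from an amine nitrogen. For the measured compounds named here, two measured steps bear on this, since both changed the same outer end of the molecule. The step of a 1.8-fold lower number from compound 1 to compound 3 (0.26 log units; within the scatter) and the step of a 1.7-fold lower number from compound 2 to compound 3 (0.23 log units; within the scatter) each stayed within the scatter. In this assay, therefore, no step beyond the scatter is expected in either direction, and the expected step is no change at the digits printed from compound 3 to compound 4 (within the scatter). Compound 4 is estimated at 2500 nM, with a range from 1200 nM to 5200 nM.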

Compound 4, half-maximal inhibitory concentration: > 10000 nM
Compound 4 ended at the assay's limit; the forecaster's own chance of this, stated with the estimate: 3%; middle value at least 4.0-fold (0.60 log units) away from the limit.
By their numbers in this assay, from the lowest: compounds 3, 2 and 1 (each within the scatter of the next). At a limit, above all of these: compound 4.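

Compound 4 gives > 10000 nM in this assay, which is a limit of the assay and not a number: the limit of > 10000 nM in this assay, at which 1 of the 4 values shown sits.
The steps to it read as an at least 4.0-fold higher number from compound 3 to compound 4 (0.60 log units; beyond the scatter) and an at least 2.3-fold higher number from compound 2 to compound 4 (0.37 log units; beyond the scatter) and also an at least 2.1-fold higher number from compound 1 to compound 4 (0.33 log units; beyond the scatter), all beyond the scatter. For the compounds shown here, earlier changes at this outer end of the chain stayed within the scatter, so dimethylamino in place of acetamido is the first change here to weaken inhibition clearly. On these data alone, whether a primary amine, a carboxylic acid or a longer chain ending in acetamido would stay close to compound 3 or fall away like compound 4 remains open.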